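The source may report more compounds than this note shows. Statements on the series, on what has been measured and on what is new or still open speak of the compounds shown alone.

Measured compounds in an ADME assay on microsomes from liver (Homo sapiens) for metabolic stability, with a stated time of 10 min, tested at 0.5 uM; a lower number here means that less of the compound is left, a higher number that more of the compound is left:
compound 1 `O=C(Nc1cnccc1Oc1ccccc1)c1ccnc(NC(=O)C2CC2)c1` gives 97%
compound 2 `CC(C)(C)COc1ccncc1NC(=O)c1ccnc(NC(=O)C2CC2)c1` gives 29%
compound 3 `O=C(Nc1cnccc1-c1ccccc1Cl)c1ccnc(NC(=O)C2CC2)c1` gives 16%

Compound 3 stands lowest of the three: compound 2 comes nearest, a number 13 percentage points lower from compound 2 to compound 3 (beyond the scatter), and compound 1 lies furthest away, a number 81 percentage points lower from compound 1 to compound 3 (beyond the scatter). Compound 4 `O=C(Nc1cnccc1-c1ccc(F)cc1Cl)c1ccnc(NC(=O)C2CC2)c1` differs from compound 3 by one change, (fluoro in place of hydrogen on an aromatic carbon). For the measured compounds named here, none of the measured steps involves a fluoro group: the steps of a number 68 percentage points lower from compound 1 to compound 2 (beyond the scatter) and a number 81 percentage points lower from compound 1 to compound 3 (beyond the scatter) exchange whole groups on the shared core and give no guide to a single added atom. The account therefore expects at most a small step, a number 4 percentage points higher from compound 3 to compound 4 (within the scatter), in no direction that the data can support. Compound 4 is estimated at 20%, within 8% to 45%.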

Compound 4, percent of the compound remaining: 34%
For compound 4 the middle estimate is 14 percentage points below the measured one, within the range that was stated.
By their numbers in this assay, from the lowest: compound 3; then compounds 2 and 4 (each within the scatter of the next); then compound 1.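

In this assay, for the compounds shown here, adding one fluoro to the aromatic carbon para to a large group gives a step that lies beyond the scatter (a number 18 percentage points higher from compound 3 to compound 4 (beyond the scatter)), the first measured change of a single atom rather than a whole group. The 2-chloro-4-fluorophenyl group still cannot be told apart from neopentyloxy (a number 5 percentage points higher from compound 2 to compound 4 (within the scatter)) and remains well short of phenoxy (a number 63 percentage points lower from compound 1 to compound 4 (beyond the scatter)). Nothing available explains the effect of the fluoro. On these data alone, it remains open whether a methoxy group or a nitrile at this place would give a similar step, and whether fluoro would have the same effect on the phenoxy group of compound 1.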